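Adding a Fluorine Partner to the Aryl Chloride

This account rests on a few compounds, and the source may have more. Where it says the series, first, only, none or still open, it means among the compounds named here.

Compound 1 `CC1(C)Oc2ccc(C#N)cc2[C@@H](NC(=O)c2ccccc2)[C@@H]1O`: 30 nM
Compound 2 `COC(=O)c1cc2ccccc2n1[C@@H]1c2cc(C#N)ccc2OC(C)(C)[C@H]1O`: 33100 nM
Compound 3 `CC1(C)Oc2ccc(C#N)cc2[C@@H](/N=C(\NC#N)Nc2cccc(Cl)c2)[C@@H]1O`: 600 nM

Of the compounds shown here, three share a core and have been measured in a functional assay (aorta) with Rattus norvegicus as the target; on this read-out higher numbers stand for weaker inhibition and lower numbers for stronger inhibition. Compound 3 stands second highest of the three numbers. Its nearest neighbour is compound 1, whose lower number lies beyond the scatter of the measurement, so compound 1 inhibits more strongly. Compound 2 has a much higher number, also beyond the scatter, and is the weakest inhibitor of the three.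

Compound 4 `CC1(C)Oc2ccc(C#N)cc2[C@@H](/N=C(\NC#N)Nc2ccc(Cl)c(F)c2)[C@@H]1O` has not yet been measured in this assay. It differs from compound 3 in one place: 4-chloro-3-fluorophenyl in place of 3-chlorophenyl on an amine nitrogen. Among the compounds with values here, no measured pair in this set isolates that change, so there is no direct precedent for its size or direction. The expected step of a 1.2-fold lower number from compound 3 to compound 4 (0.08 log units; within the scatter) is small, within the scatter, since the aryl group keeps its ring and its chlorine and only gains a fluorine. Compound 4 is therefore estimated at 500 nM, with a range from 150 nM to 2000 nM.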

Compound 4, half-maximal inhibitory concentration: 1660 nM
For compound 4 the middle estimate is 3.3-fold (0.52 log units) below the measured one, and the stated range covers the measured number.
By their numbers in this assay, from the lowest: compound 1; then compound 3; then compound 4; then compound 2.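

Within this assay the swap of 3-chlorophenyl for 4-chloro-3-fluorophenyl on the amine nitrogen gives a 2.8-fold higher number from compound 3 to compound 4 (0.44 log units; beyond the scatter) and so weakens inhibition, modestly but beyond the scatter. Within the data shown here, this is the first step in the set that isolates this position, and it shows that the read-out responds to the substituents on the aryl group even when the aromatic ring itself stays. Among these compounds, the group names show that the change both adds a fluorine and alters the numbered place of the chlorine, and the single step cannot divide its effect between the two; nothing available explains the loss.

A 4-chlorophenyl or a 3-fluorophenyl group at this place would help separate those two contributions. From the compounds shown here alone, whether an unsubstituted phenyl group would inhibit more or less strongly than compound 3 remains open.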